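The source may hold more compounds than are shown below. What is called first, only, known or untested is meant among the compounds shown, and "the series" means these compounds.

Compound 1, `CCOC(=O)c1c(O)c2cccnc2n(-c2ccccc2)c1=O`, gives 15.5% in a functional assay on the whole organism for inhibition, with Rattus norvegicus as the target, read by cytopathic effect and paw edema, at a dose of 100 mg/kg by the oral route; a higher number here means more inhibition at the dose given (going by the name of the read-out), a lower number less inhibition.
Compound 2, `O=C(Nc1ccccn1)c1c(O)c2cccnc2n(-c2ccccc2)c1=O`, gives 14.6%.
Compound 3, `COc1ccc(NC(=O)c2c(O)c3cccnc3n(-c3ccccc3)c2=O)cc1`, gives -1.9%.

Compound 1 holds the highest of these three numbers, although its step to compound 2 lies within the scatter; only compound 3 falls clearly beyond it. Compound 4, `COc1cccc(NC(=O)c2c(O)c3cccnc3n(-c3ccccc3)c2=O)c1`, differs from compound 1 in one place: (3-methoxyphenyl)amino in place of ethoxy on a carbonyl carbon. The step that bears most on this is a number 17.4 percentage points lower from compound 1 to compound 3 (beyond the scatter), where a (4-methoxyphenyl)amino group took the place of the same ethoxy. By contrast, a number 0.9 percentage points lower from compound 1 to compound 2 (within the scatter) shows that a (pyridin-2-yl)amino amide changed little, and a number 16.5 percentage points lower from compound 2 to compound 3 (beyond the scatter) separates the two amides. The expected step for compound 4 is a modest fall, a number 12.5 percentage points lower from compound 1 to compound 4 (beyond the scatter), because compound 3 with the nearest group gives -1.9%. The estimate for compound 4 in this assay is 3%, ranging from -12% to 18%.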

Compound 4, a percentage reported as inhibition, in the whole organism at one dose (the size of the read-out at that dose, not a potency): 20.7%
Compound 4: the middle estimate sits 17.7 percentage points below what was measured, and the stated range ends below it.
By their numbers in this assay, from the lowest: compound 3; then compounds 2, 1 and 4 (each within the scatter of the next).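

Placing 3-methoxyphenyl instead of 4-methoxyphenyl on the amide-type nitrogen gives a number 22.6 percentage points higher from compound 3 to compound 4 (beyond the scatter) in this assay, so for this pair the place of the methoxy group on the ring changes the result. Compound 3 therefore does not speak for all amides here. With (3-methoxyphenyl)amino in place of ethoxy, the result is a number 5.2 percentage points higher from compound 1 to compound 4 (within the scatter) and with 3-methoxyphenyl in place of pyridin-2-yl it is a number 6.1 percentage points higher from compound 2 to compound 4 (within the scatter) so these three compounds cannot be put in order.

From the compounds shown here alone, how a plain phenyl group on the amide nitrogen would fare remains open. Nothing available here explains the gap between the two methoxyphenyl amides.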